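Cyclopropyl for methyl on the amide carbonyl, second core

The compounds below may be only part of what the source reports. "The series", "measured", "known", "first", "only" and "open" are said of these compounds alone.

Measured so far:
compound 1 `CC(=O)Nc1ccc(-c2cn([C@@H]3CN[C@H](C(=O)Nc4ccc(Cl)c(C(F)(F)F)c4)C3)nn2)cn1` gives 8980 nM in a functional assay on K562 cells (Homo sapiens) for inhibition, read by MTT assay, with a stated time of 48 h; a higher number here means a weaker inhibitor, a lower number a stronger inhibitor
compound 2 `O=C(Nc1ccc(-c2cn([C@@H]3CN[C@H](C(=O)Nc4ccc(Cl)c(C(F)(F)F)c4)C3)nn2)cn1)C1CC1` gives 8770 nM in this assay
compound 3 `CC(=O)Nc1n[nH]c2cc(-c3cn([C@@H]4CN[C@H](C(=O)Nc5ccc(Cl)cc5Cl)C4)nn3)ccc12` gives 2090 nM in this assay

Compound 1 and compound 2 share one core and differ only by cyclopropyl in place of methyl on a carbonyl carbon. That change produced a 1.0-fold lower number from compound 1 to compound 2 (0.01 log units; within the scatter), so within this pair the two numbers cannot be told apart.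

Compound 3 carries a different core; the difference between the core of compound 1 and the core of compound 3 is not broken down here. In this assay compound 3 stands lowest of the three, with compound 2 and compound 1 both beyond the scatter above it.

Compound 4 `O=C(Nc1n[nH]c2cc(-c3cn([C@@H]4CN[C@H](C(=O)Nc5ccc(Cl)cc5Cl)C4)nn3)ccc12)C1CC1` is the counterpart of compound 3 and is not yet measured. It differs from compound 3 by cyclopropyl in place of methyl on a carbonyl carbon. The place of the change is the same, word for word, as in the pair compound 1 to compound 2, so this is the same change set on the second core.

Among the measured compounds shown here, the only guide is the earlier pair: because a 1.0-fold lower number from compound 1 to compound 2 (0.01 log units; within the scatter) showed no movement, the step from compound 3 to compound 4 is expected to be a 1.0-fold lower number from compound 3 to compound 4 (0.02 log units; within the scatter), essentially flat. On that basis compound 4 is estimated at 2000 nM, with a likely range from 900 nM to 4500 nM; this rests on a single precedent and may not carry across cores.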

Compound 4, half-maximal inhibitory concentration: 5340 nM
Beside the measured number, compound 4's estimate is 2.7-fold (0.43 log units) below it, outside the stated range (above it).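

On the second core, in this assay, cyclopropyl in place of methyl on a carbonyl carbon produces a 2.6-fold higher number from compound 3 to compound 4 (0.41 log units; beyond the scatter), whereas the same change on the first core gave a 1.0-fold lower number from compound 1 to compound 2 (0.01 log units; within the scatter). Set side by side, the two steps cannot be told apart, even though only the second lies beyond the scatter on its own: the same change on two cores in this assay, a 1.0-fold lower number (0.01 log units; within the scatter) from compound 1 to compound 2 and a 2.6-fold higher number (0.41 log units; beyond the scatter) from compound 3 to compound 4, 2.6-fold (0.42 log units) apart, within the scatter of two such steps. Among the compounds shown here, this fits a single small effect of the change on both cores, but it does not show that the two cores respond alike, and with only one pair per core it does not show that they respond differently either.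

The compounds shown leave open how the series responds to other groups on this carbonyl carbon, such as an amine or a longer chain like n-butyl, and whether a larger step would separate the two cores more clearly. For the compounds shown here, also open is which part of the difference between the core of compound 1 and the core of compound 3 governs the size of the step, as these two compounds differ in more than one place and no pair here isolates either part.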